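The compounds below may be only part of what the source reports. "The series", "measured", "known", "first", "only" and "open" are said of these compounds alone.

In a functional assay on DU-145 cells (Homo sapiens) for inhibition, read by trypan blue exclusion, with a stated time of 96 h (a lower number here means a stronger inhibitor of growth, a higher number a weaker inhibitor of growth), compound 1 `COc1ccccc1/C=C(/SCc1ccc(F)cc1)C(=O)c1ccc(Br)cc1` gives 10000 nM, compound 3 `COc1ccccc1/C=C(/SCc1ccc(F)cc1)C(=O)c1ccc(Cl)cc1` gives 10000 nM and compound 2 `COc1ccccc1/C=C(/Sc1ccc(C)cc1)C(=O)c1ccc(Br)cc1` gives 9000 nM, all within the scatter of each other. Compound 4 `O=C(/C(=C\c1ccc(O)cc1)SCc1ccc(F)cc1)c1ccc(Br)cc1` carries 4-hydroxyphenyl in place of 2-methoxyphenyl on a double-bonded chain carbon bound to a double-bonded chain carbon. Among the measured compounds shown here, two measured steps bear on it only indirectly: 4-methylphenyl in place of 4-fluorobenzyl on a sulfur gave a 1.1-fold lower number from compound 1 to compound 2 (0.05 log units; within the scatter), and chloro in place of bromo gave no change at the digits printed from compound 1 to compound 3 (within the scatter). Neither touches this place, so the data hold no direct measure of the change. The expected step is small and not clearly beyond the scatter, estimated as a 1.4-fold lower number from compound 1 to compound 4 (0.15 log units; within the scatter). For compound 4 the estimate is 7000 nM, with an expected range of 2000 nM to 14000 nM.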

Compound 4, concentration for 50% growth inhibition: 10000 nM
The estimate for compound 4 lay 1.4-fold (0.15 log units) below the measured number; measured number inside the range.
By their numbers in this assay, from the lowest: compounds 2, 1, 3 and 4 (each within the scatter of the next).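

In this assay, 4-hydroxyphenyl in place of 2-methoxyphenyl on a double-bonded chain carbon bound to a double-bonded chain carbon gave no change at the digits printed from compound 1 to compound 4 (within the scatter). Among the compounds shown here, this is the first direct reading at this place, which the earlier steps did not touch, and this exchange, which brings a hydrogen-bond donor, leaves the number level with that of compound 1. Nothing at hand accounts for this result. The compounds shown leave open whether 4-aminophenyl or 4-carboxyphenyl at this place would move the number beyond the scatter.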